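The source may hold more compounds than are shown below. What is called first, only, known or untested is meant among the compounds shown, and "the series" means these compounds.

Of the compounds shown here, three sharing one core have been measured. Compound 1 `c1ccc(-c2nnc(-c3nsc4ccccc34)o2)cc1` carries a phenyl group on the core, while compound 2 `CNc1nnc(-c2nsc3ccccc23)o1` and compound 3 `CCNc1nnc(-c2nsc3ccccc23)o1` carry an amino group there instead. In a functional assay on the whole organism for inhibition, with Rattus norvegicus as the target, with a stated time of 2 h, at a dose of 100 mg/kg by the intraperitoneal route (on this read-out lower numbers stand for less inhibition and higher numbers for more inhibition at the one dose given (going by the name of the read-out)), compound 1 gives 60%. In this assay compound 2 gives 67%, and compound 3 gives 65%. The three numbers sit close together: there is a number 7 percentage points higher from compound 1 to compound 2 (within the scatter), a number 5 percentage points higher from compound 1 to compound 3 (within the scatter) and a number 2 percentage points lower from compound 2 to compound 3 (within the scatter), so compound 3 cannot be set apart from either neighbour on these numbers alone.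

Compound 4 `Clc1ccc(Nc2nnc(-c3nsc4ccccc34)o2)cc1` is the next step from compound 3: 4-chlorophenyl in place of ethyl on a nitrogen on an aromatic ring. Among the measured compounds shown here, only one measured step touches the same nitrogen, namely a number 2 percentage points lower from compound 2 to compound 3 (within the scatter), and that was a small change of the chain on that nitrogen. For the measured compounds named here, no measured step replaces a chain on that nitrogen with an aromatic ring, so the only guidance is that the group on this nitrogen has so far made little difference. The expectation is therefore a step of no change at the digits printed from compound 3 to compound 4 (within the scatter), with a wide range because the change is larger than anything yet tested. Compound 4 is estimated at 65%, expected to lie between 45% and 82%.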

Compound 4, a percentage reported as inhibition, in the whole organism at one dose (the size of the read-out at that dose, not a potency): 48%
Beside the measured number, compound 4's estimate is 17 percentage points above it; measured number inside the range.
By their numbers in this assay, from the lowest: compound 4; then compounds 1, 3 and 2 (each within the scatter of the next).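

The group on this nitrogen turns out to matter in this assay: putting 4-chlorophenyl in place of ethyl gives a number 17 percentage points lower from compound 3 to compound 4 (beyond the scatter), and putting it in place of methyl gives a number 19 percentage points lower from compound 2 to compound 4 (beyond the scatter). Among the compounds shown here, the earlier compounds could not show this, as their only change on this nitrogen was the small chain step, a number 2 percentage points lower from compound 2 to compound 3 (within the scatter), so the position had looked indifferent only for two short chains. Nothing measured here accounts for the lower number with 4-chlorophenyl.

The change also brings in several things at once, a six-membered aromatic ring, a chlorine and more heavy atoms, and the compounds shown leave open which of these goes with the step; a plain phenyl on the same nitrogen would begin to separate the ring from the chlorine. Also open, as far as these compounds go, is where a longer chain such as butyl, or a saturated ring such as cyclohexyl, would fall, and so whether the number changes with the size of the group on this nitrogen or with the presence of an aromatic ring.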